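This account rests on a few compounds, and the source may have more. Where it says the series, first, only, none or still open, it means among the compounds named here.

Measured so far:
- compound 1 `ClCc1ccccc1Cn1cnc2c(Cl)nc(Cl)nc21`: 4780 nM
- compound 2 `ClCc1ccccc1Cn1cnc2ncnc(Cl)c21`: 33100 nM
- compound 3 `ClCc1cccc(Cn2cnc3nc(Cl)nc(Cl)c32)c1`: 2810 nM

These three compounds were tested in a functional assay on A498 cells (Homo sapiens) for cytotoxicity, read by sulforhodamine B assay, with a stated time of 48 h; on this read-out lower numbers stand for stronger inhibition of growth and higher numbers for weaker inhibition of growth. Compound 2 stands at the top of the three numbers, which here means the weakest growth inhibition. Its nearest neighbour is compound 1, whose number is lower by a margin well beyond the usual scatter, and compound 3 lies further away still, with a yet lower number. So compound 2 is clearly the least active of the three.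

Compound 4 `ClCc1ccccc1Cn1cnc2nc(Cl)nc(Cl)c21` has not been measured. It arises from compound 2 by a single change: chloro in place of hydrogen on an aromatic carbon. The new chloro sits on the six-membered ring of the shared core, between two ring nitrogen atoms and meta to the chloro group already there. Going by the values given here, no pair of measured compounds differs by exactly this change, so its effect must be guessed. Compound 1 and compound 3 both carry a second chloro on the core and both give markedly lower numbers than compound 2, which points toward a sizeable drop in this assay. Compound 4 is therefore expected to give a number close to those two, in the region of 4000 nM, within a range of 1500 nM to 12000 nM. The step from compound 2 to compound 4 is thus estimated as an 8.3-fold lower number from compound 2 to compound 4 (0.92 log units; beyond the scatter), a move toward stronger growth inhibition.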

Compound 4, concentration for total growth inhibition: 5880 nM
Compound 4: middle estimate off by 1.5-fold (0.17 log units), on the low side; measured number inside the range.
By their numbers in this assay, from the lowest: compounds 3, 1 and 4 (each within the scatter of the next, the first and the last beyond it); then compound 2.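

In this assay, chloro in place of hydrogen on this aromatic carbon, between two ring nitrogen atoms, gives a 5.6-fold lower number from compound 2 to compound 4 (0.75 log units; beyond the scatter) and so moves toward stronger growth inhibition. The earlier compounds shown here could only hint at this effect, since no measured pair isolated the change. Here, the rest of the molecule stays the same, so the step can be assigned to this one swap, and it lies beyond the usual scatter. Nothing shown here explains why a chloro at this position changes the read-out.

The compounds shown leave open whether chloro itself matters at this position or whether another group, such as an amine, a methoxy group or a methyl group, would give a similar number. They also leave open whether the same swap would produce a step of similar size with the chloromethyl group placed as in compound 3, since the partner of compound 3 carrying hydrogen on this carbon does not appear among them.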